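This account rests on a few compounds, and the source may have more. Where it says the series, first, only, none or still open, it means among the compounds named here.

Measured in a functional assay on HepG2 cells (Homo sapiens) for inhibition, read by MTT assay, with a stated time of 72 h; a higher number here means a weaker inhibitor, a lower number a stronger inhibitor:
- Compound 1 `CCc1ccc(NC(=O)C2CCN(C/C=C/c3ccccc3)CC2)cc1`: 23300 nM
- Compound 2 `COc1ccc(NC(=O)C2CCN(C/C=C/c3ccccc3)CC2)cc1`: 88800 nM

Compound 2, at 88800 nM, has the higher number of the pair and is the weaker inhibitor. Compound 3 `CN1CCN(c2ccc(NC(=O)C3CCN(C/C=C/c4ccccc4)CC3)cc2)CC1` carries 4-methylpiperazin-1-yl in place of methoxy on an aromatic carbon. Going by the values given here, one measured step bears on this change: methoxy in place of ethyl gave a 3.8-fold higher number from compound 1 to compound 2 (0.58 log units; beyond the scatter), a modest step beyond the scatter. A step of similar size is therefore expected in this assay, tentatively towards a lower number, although the data do not settle the direction. The expected change is a 3.0-fold lower number from compound 2 to compound 3 (0.47 log units; beyond the scatter). Compound 3 is estimated at 30000 nM, within a range of 8000 nM to 100000 nM.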

Compound 3, half-maximal inhibitory concentration: 35200 nM
Beside the measured number, compound 3's estimate is 1.2-fold (0.07 log units) below it; the measured number falls inside the stated range.
By their numbers in this assay, from the lowest: compounds 1 and 3 (each within the scatter of the next); then compound 2.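

In this assay, this aromatic carbon accepts 4-methylpiperazin-1-yl, a much larger group with a six-membered non-aromatic ring, without a loss: replacing methoxy gives a 2.5-fold lower number from compound 2 to compound 3 (0.40 log units; beyond the scatter). Against ethyl, the same group gives a 1.5-fold higher number from compound 1 to compound 3 (0.18 log units; within the scatter), so among these three groups methoxy alone stands apart. Nothing available explains this result. Going by these compounds, it remains open whether a chlorine atom, a carboxylic acid or a longer chain at this carbon would match ethyl and 4-methylpiperazin-1-yl or methoxy.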